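Notes on swapping the substituent at the shared core

The source may report more compounds than this note shows. Statements on the series, on what has been measured and on what is new or still open speak of the compounds shown alone.

Three compounds of the series have been run in a functional assay on CHO cells for agonist activity at Free fatty acid receptor 2 (Homo sapiens), read by cAMP accumulation; a higher number here means a larger maximal response, a lower number a smaller maximal response. Compound 1 `CC(C)(C)[C@H](C(=O)Nc1ncc(F)s1)c1ccc(Cl)cc1` gives 92%. Compound 2 `CSc1cnc(NC(=O)[C@H](c2ccc(Cl)cc2)C(C)(C)C)s1` gives 109%. Compound 3 `CC(C)(C)[C@H](C(=O)Nc1ncc(Cc2ccc(Cl)cc2)s1)c1ccc(Cl)cc1` gives 100%. On these numbers compound 3 stands second highest of three; its nearest neighbour is compound 1, and the two lie within the scatter of each other, as do compound 3 and compound 2. Among the compounds with values here, the one step beyond the scatter is a number 17 percentage points higher from compound 1 to compound 2 (beyond the scatter). The steps of a number 8 percentage points higher from compound 1 to compound 3 (within the scatter) and a number 9 percentage points lower from compound 2 to compound 3 (within the scatter) both stay within the scatter.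

Compound 4 `CN(C)c1cnc(NC(=O)[C@H](c2ccc(Cl)cc2)C(C)(C)C)s1` is not yet measured. It differs from compound 3 thus: dimethylamino in place of 4-chlorobenzyl on an aromatic carbon. Within the data shown here, no measured step brings in a dimethylamino group, so the bearing steps are indirect: a number 9 percentage points lower from compound 2 to compound 3 (within the scatter) shows that the exchange between methylsulfanyl and 4-chlorobenzyl at that position moved the maximal response only within the scatter, and a number 8 percentage points higher from compound 1 to compound 3 (within the scatter) shows the same for the exchange between fluoro and 4-chlorobenzyl. Across all three substituents tried at that position the maximal response stays close to the reference, so for compound 4 a step of no more than the scatter is expected, a number 2 percentage points higher from compound 3 to compound 4 (within the scatter). Compound 4 is estimated at 102%, with a range from 85% to 118%.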

Compound 4, largest response reached (reported as efficacy), in percent of the reference or control that the assay uses: 112%
Compound 4: the middle estimate sits 10 percentage points below what was measured; the range from low to high includes it.
By their numbers in this assay, from the lowest: compounds 1, 3, 2 and 4 (each within the scatter of the next, the first and the last beyond it).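

In this assay, replacing 4-chlorobenzyl with dimethylamino at this position gives the first step out of compound 3 that passes the scatter (a number 12 percentage points higher from compound 3 to compound 4 (beyond the scatter)), so the substituent here can shift the maximal response even though both earlier steps involving 4-chlorobenzyl stayed within it. Dimethylamino also stands clear of fluoro (a number 20 percentage points higher from compound 1 to compound 4 (beyond the scatter)) but cannot be separated from methylsulfanyl (a number 3 percentage points higher from compound 2 to compound 4 (within the scatter)); compound 2 and compound 4 thus form a pair that both lie beyond the scatter from compound 1, while compound 3 is separated from compound 1 by no such margin and so sits outside this grouping. Nothing at hand gives a reason for any of these differences.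

The compounds shown leave open whether a methoxy group, a primary amine or a cyclic amine such as morpholine would fall with dimethylamino and methylsulfanyl or with fluoro. They also leave open whether an unsubstituted benzyl group would behave like 4-chlorobenzyl at this position.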